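The source may hold more compounds than are shown below. What is called first, only, known or untested is meant among the compounds shown, and "the series" means these compounds.

Measured so far:
- Compound 1 `C/C(=N\NC(=S)Nc1ccccc1I)c1ccccn1`: 8.09 nM
- Compound 2 `CC(=NNC(=S)Nc1ccccc1)c1ccccn1`: 6.8 nM
- Compound 3 `C/C(=N/NC(=S)Nc1ccccc1I)c1ccccn1`: 8.09 nM

All three values come from a functional assay on T98G cells (Homo sapiens) for cytotoxicity, read by MTT assay, with a stated time of 48 h; on this read-out higher numbers stand for weaker inhibition and lower numbers for stronger inhibition. Compound 3, at 8.09 nM, reads the same as compound 1, and compound 2 lies within the usual scatter of compound 3.

The next compound to be tested is compound 4 `CC(=NNC(=S)Nc1ccccc1I)c1ccccn1`. The change from compound 3 involves no new group: the two compounds have the same atoms and bonds; at least one stereo element is drawn with a configuration in one of them and without one in the other: 1 of 1 stereo elements differ; a double bond is drawn Z in compound 3 and without a configuration in compound 4. E and Z name the two ways in which the groups can lie around a double bond, so the drawing of compound 4 simply leaves that choice open.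

Going by the values given here, one measured step bears on this, no change at the digits printed from compound 1 to compound 3 (within the scatter). It is a clean comparison of the two drawn forms, given (the fact that compounds 1 and 3 differ only in the configuration as drawn). Since the E and Z drawings gave the same number, either form would be expected to read alike in this assay, and so would a drawing that does not choose between them. No change beyond the scatter is therefore expected. The estimated step is no change at the digits printed from compound 3 to compound 4 (within the scatter). For compound 4 the expected value is 8.09 nM, with an estimated range of 5.5 nM to 12 nM.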

Compound 4, half-maximal inhibitory concentration: 8.1 nM
Compound 4: middle estimate off by 1.0-fold (0.00 log units), on the low side; the range from low to high includes it.
By their numbers in this assay, from the lowest: compounds 2, 1, 3 and 4 (each within the scatter of the next).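

In this assay, a drawing with no configuration at the double bond cannot be told apart from either defined drawing, with a 1.0-fold higher number from compound 3 to compound 4 (0.00 log units; within the scatter) and a 1.0-fold higher number from compound 1 to compound 4 (0.00 log units; within the scatter). Going by these compounds alone, each of these steps concerns that double bond alone: the fact that one of compounds 3 and 4 is drawn with a defined configuration and the other without, at the place where they differ The result also gives the first comparison of the iodo group that differs in one place only, since compound 2 and compound 4 are both drawn without a configuration, and iodo in place of hydrogen on an aromatic carbon gives a 1.2-fold higher number from compound 2 to compound 4 (0.08 log units; within the scatter), so this swap does not separate the two compounds in this assay.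

Iodo is the only replacement on the aromatic ring shown here, so it remains open whether chloro, an amine or a carboxylic acid at that place would also stay within the scatter of compound 2. Going by these compounds, it also remains open what a change elsewhere in the shared core, such as a longer chain, would do to the reading in this assay.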